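Methyl to propyl on the core of compound 1

The compounds below may be only part of what the source reports. "The series", "measured", "known", "first", "only" and "open" are said of these compounds alone.

Compound 1 `Cc1cnc(NC(=O)c2cc(Oc3ccc(S(C)(=O)=O)cc3)c3cn(C)nc3c2)cn1`: 20.4 10^-6 cm/s
Compound 2 `Cc1cnc(NC(=O)c2cc(Oc3ccc(S(=O)(=O)C4CC4)cc3)c3cn(C)nc3c2)cn1`: 17.8 10^-6 cm/s

In an ADME assay on MDCKII-LE cells (Canis lupus familiaris) for permeability (on this read-out lower numbers stand for lower permeability and higher numbers for higher permeability), compound 1 gives 20.4 10^-6 cm/s, the top of the two numbers shown, though a 1.1-fold lower number from compound 1 to compound 2 (0.06 log units; within the scatter) lies within the scatter. Compound 3 `CCCn1cc2c(Oc3ccc(S(C)(=O)=O)cc3)cc(C(=O)Nc3cnc(C)cn3)cc2n1` differs from compound 1 by ethyl in place of hydrogen on a saturated chain carbon bound to an aromatic nitrogen. Among the compounds with values here, the single measured step, a 1.1-fold lower number from compound 1 to compound 2 (0.06 log units; within the scatter), alters a group on the sulfonyl sulfur, not this chain, so nothing measured bears directly on the change. Within the data shown here, with only that small step as a guide, a step within the scatter is expected, a 1.1-fold higher number from compound 1 to compound 3 (0.03 log units; within the scatter). Compound 3 is therefore estimated at 22 10^-6 cm/s, between 12 10^-6 cm/s and 40 10^-6 cm/s.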

Compound 3, apparent permeability: 14.2 10^-6 cm/s
Compound 3: the middle estimate sits 1.5-fold (0.19 log units) above what was measured; the range from low to high includes it.
By their numbers in this assay, from the lowest: compounds 3, 2 and 1 (each within the scatter of the next).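

Within the data shown here, this is the first measured change at this position: methyl to propyl on the core, read in this assay, gives a 1.4-fold lower number from compound 1 to compound 3 (0.16 log units; within the scatter). So a chain carrying an added ethyl on the saturated carbon bound to the aromatic nitrogen gives a step no larger than the scatter. Nothing measured here offers a reason for this number. Still open, as far as these compounds go, is whether a longer chain, such as hexyl, or a propyl ending in an amine or a carboxylic acid would also stay within the scatter. Also open, from the compounds shown here alone, is how propyl here behaves alongside cyclopropyl on the sulfonyl sulfur.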